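The source may hold more compounds than are shown below. What is called first, only, known or untested is meant among the compounds shown, and "the series" means these compounds.

Measured compounds:
Compound 1, `O=C(NCc1cn(Cc2ccc(Cl)cc2)nn1)c1cn(-c2ccccc2)nc1-c1ccc(Cl)cc1`: in a functional assay on MIA PaCa-2 cells (Homo sapiens) for antiproliferative activity, read by sulforhodamine B assay, with a stated time of 48 h (a lower number here means a stronger inhibitor of growth, a higher number a weaker inhibitor of growth), compound 1 gives 410 nM.
Compound 2, `COc1ccc(Cn2cc(CNC(=O)c3cn(-c4ccccc4)nc3-c3ccc(Cl)cc3)nn2)cc1`: in this assay compound 2 gives 290 nM.

Among the compounds with values here, compound 2 has the lowest of the two numbers so far, but its nearest neighbour, compound 1, is separated from it only by a 1.4-fold lower number from compound 1 to compound 2 (0.15 log units; within the scatter), a gap that falls within the scatter, so the two compounds cannot be ranked against each other.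

Compound 3, `COc1ccc(Cn2cc(CNC(=O)c3cn(-c4ccccc4)nc3-c3ccc(Cl)cc3)nn2)cc1OC`, has not been measured in this assay. It differs from compound 2 by methoxy in place of hydrogen on an aromatic carbon, placed on an aromatic carbon of a six-membered aromatic ring of carbon only, ortho to a methoxy group and meta to a large group; read one bond further out, the 4-methoxybenzyl of compound 2 becomes 3,4-dimethoxybenzyl.

Within the data shown here, the only measured step that bears on this part of the molecule is a 1.4-fold lower number from compound 1 to compound 2 (0.15 log units; within the scatter), which lay within the scatter. Among the measured compounds shown here, no measured step adds a second methoxy group on this ring. On that basis compound 3 is expected to sit close to compound 2, with a step of a 1.1-fold lower number from compound 2 to compound 3 (0.05 log units; within the scatter), and its estimated value in this assay is 260 nM, with a range from 100 nM to 700 nM.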

Compound 3, concentration for 50% growth inhibition: 9400 nM
The estimate for compound 3 lay 36-fold (1.56 log units) below the measured number; the measured number lies above the stated range.
By their numbers in this assay, from the lowest: compounds 2 and 1 (each within the scatter of the next); then compound 3.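

In this assay, adding a methoxy group on the aromatic carbon ortho to a methoxy group and meta to a large group gives a 32-fold higher number from compound 2 to compound 3 (1.51 log units; beyond the scatter) and turns the 4-methoxybenzyl of compound 2 into a 3,4-dimethoxybenzyl. Exchanging the whole 4-chlorophenyl for 3,4-dimethoxyphenyl gives a 23-fold higher number from compound 1 to compound 3 (1.36 log units; beyond the scatter) as well, so compound 3 stands apart from both earlier compounds, whereas the exchange of chloro for methoxy had stayed within the scatter and had given no sign that this ring could be so sensitive to a single added group. Among these three compounds, then, the ring tolerates either chloro or methoxy at its 4-position, yet growth inhibition is largely lost once methoxy groups occupy both the 3- and 4-positions, and nothing available explains that loss.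

The compounds shown leave open whether the loss follows from a methoxy group at the 3-position alone or only from the pair of methoxy groups together. They also leave open how a fluorine atom, a hydroxy group, an ethoxy group or an amine on that same carbon would read in this assay.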